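Chloro on the benzylsulfanyl arm: notes on a small series

This account rests on a few compounds, and the source may have more. Where it says the series, first, only, none or still open, it means among the compounds named here.

Measured so far in a functional assay on the whole organism (artery, strain albino) with Rattus norvegicus as the target, with a stated time of 360 min, at a dose of 10 mg/kg by the oral route; a higher number here means more inhibition at the dose given (going by the name of the read-out), a lower number less inhibition:
compound 1 `COc1ccc(C2N=C(SCc3ccccc3)NC(C)=C2C(=O)Nc2ccc(F)cc2)cc1OC` gives 3.6%
compound 2 `COc1ccc(C2N=C(SCc3ccccc3Cl)NC(C)=C2C(=O)Nc2ccc(F)cc2)cc1OC` gives 39.2%
compound 3 `CC1=C(C(=O)Nc2ccc([N+](=O)[O-])cc2)C(c2ccc(Br)cc2)N=C(SCc2ccccc2)N1` gives 37.6%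

Compound 1 and compound 2 share one core and differ only by chloro in place of hydrogen on an aromatic carbon. That single change produced a number 35.6 percentage points higher from compound 1 to compound 2 (beyond the scatter). Compound 3 sits on a different core; the difference between the cores of compound 1 and compound 3 is not broken down here. The numbers for compound 2 and compound 3 lie within the scatter of each other, so no order between them is read.

Compound 4 `CC1=C(C(=O)Nc2ccc([N+](=O)[O-])cc2)C(c2ccc(Br)cc2)N=C(SCc2ccccc2Cl)N1` is not yet measured. It differs from compound 3 by chloro in place of hydrogen on an aromatic carbon, the same change as that from compound 1 to compound 2. An upward step is expected because a number 35.6 percentage points higher from compound 1 to compound 2 (beyond the scatter), though the starting value of compound 3 is already higher, so the expected step is a number 17.4 percentage points higher from compound 3 to compound 4 (beyond the scatter). Compound 4 is estimated at 55% in this assay, resting on one precedent alone.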

Compound 4, a percentage reported as inhibition, in the whole organism at one dose (the size of the read-out at that dose, not a potency): 13.9%
For compound 4 the middle estimate is 41.1 percentage points above the measured one; measured number outside the range, below it.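

In this assay, replacing benzylsulfanyl with (2-chlorobenzyl)sulfanyl on the core of compound 3 gives a number 23.7 percentage points lower from compound 3 to compound 4 (beyond the scatter), so the step seen on the core of compound 1 does not carry over in direction or size: the same change on two cores in this assay, a number 35.6 percentage points higher (beyond the scatter) from compound 1 to compound 2 and a number 23.7 percentage points lower (beyond the scatter) from compound 3 to compound 4, 59.3 percentage points apart, beyond the scatter of two such steps

This shows that, in these two pairs, the outcome of the chloro change depends on the core it is placed on. It does not show which difference between the cores is responsible, since the fluoro and two methoxy groups of compound 1 stand against the nitro and bromo groups of compound 3.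

The compounds shown leave open how a methyl, a methoxy or an amine in place of the chloro would read on either core. They also leave open whether a longer chain in place of the benzyl would follow either pair.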